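Four Analogues in a Cardiac Cytotoxicity Screen

A few compounds are considered here, and "the series" means these few. Any claim that something is new, unique, unknown or untested is made for them only; others in the source may bear on it.

The series was examined in a toxicity assay (H9c2 cells) for cytotoxicity, with Rattus norvegicus as the target, read by neutral red uptake, with a stated time of 72 h; a lower number here means a stronger inhibitor, a higher number a weaker inhibitor. Compound 1, `C/C(=N\NC(=O)c1ccc(-c2ccccc2)cc1)c1ccccc1O`, gives > 100000 nM there, a value that is a limit of the assay rather than a number. Compound 3, `CC/C(=N\NC(=O)c1ccc(-c2ccccc2)cc1)c1ccccc1O`, differs from compound 1 by the change (methyl in place of hydrogen on a saturated chain carbon bound to a carbon with a double bond to nitrogen). In this assay compound 3 gives > 100000 nM, again a limit. The step that the two limits leave unreadable from compound 1 to compound 3 therefore cannot be read in size. Compound 2, `C/C(=N\NC(=O)c1cccc2ccccc12)c1ccccc1O`, is built on a different core; the difference between the two cores is not broken down here. In this assay compound 2 gives > 200000 nM, which is also a limit. Compound 4, `CC/C(=N\NC(=O)c1cccc2ccccc12)c1ccccc1O`, has not yet been measured. It stands to compound 2 as compound 3 stands to compound 1, carrying the same change, (methyl in place of hydrogen on a saturated chain carbon bound to a carbon with a double bond to nitrogen). Within the data shown here, of the three values shown, two sit at the limit of > 100000 nM in this assay, at which 2 of the 3 values shown sit, and one at the limit of > 200000 nM in this assay, at which 1 of the 3 values shown sits; no compound in the set has been given an actual number. Because of the limit of > 200000 nM in this assay, at which 1 of the 3 values shown sits, compound 4 is expected to remain at a limit as well, so the step that the limit leaves unreadable from compound 2 to compound 4 is expected to be flat. Compound 4 is estimated at 300000 nM, between 100000 nM and 1000000 nM, and the chief expectation is that this assay will again report only a limit for it.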

Compound 4, half-maximal inhibitory concentration: > 200000 nM
Compound 4: only a limit was reported (the forecaster's own chance of this, stated with the estimate: 85%); the middle value lies beyond the limit too.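

Compound 4, like compound 2, is reported only as a limit and not as a number, so the step from compound 2 to compound 4 cannot be read in size, and the same holds for the step from compound 1 to compound 3. The compounds shown leave open what effect, if any, methyl in place of hydrogen has in this assay, and where any of the four compounds would give an actual number there.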